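A methyl-to-chloro swap on compound 1

The source may report more compounds than this note shows. Statements on the series, on what has been measured and on what is new or still open speak of the compounds shown alone.

Compound 1 `Cc1ccc(S(=O)(=O)N(C)C(=O)NC(C)c2cc(Br)ccc2OCc2ccccc2)cc1` gives 67100 nM
Compound 2 `CCOc1ccc(Br)cc1C(C)NC(=O)N(C)S(=O)(=O)c1ccc(C)cc1` gives 28600 nM

In a functional assay on thoracic aorta (Rattus norvegicus, strain Wistar), with a stated time of 15 min (on this read-out lower numbers stand for an effect already at smaller amounts and higher numbers for an effect only at larger amounts of compound), compound 1 has the higher of the two numbers, 67100 nM. Compound 3 `CC(NC(=O)N(C)S(=O)(=O)c1ccc(Cl)cc1)c1cc(Br)ccc1OCc1ccccc1` carries chloro in place of methyl on an aromatic carbon, para to a large group (chloro in place of methyl on an aromatic carbon). Going by the values given here, no measured step covers this change. The only one, a 2.3-fold lower number from compound 1 to compound 2 (0.37 log units; beyond the scatter), is modest and concerns a different group, so it offers only a loose guide to size. A small step towards a lower number is therefore expected, and it may not clear the scatter. The expected change is a 1.3-fold lower number from compound 1 to compound 3 (0.13 log units; within the scatter). Compound 3 is estimated at 50000 nM, within an expected range of 20000 nM to 125000 nM.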

Compound 3, half-maximal effective concentration: 146000 nM
Compound 3: middle estimate off by 2.9-fold (0.47 log units), on the low side; the whole stated range lies below it.
By their numbers in this assay, from the lowest: compound 2; then compound 1; then compound 3.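

In this assay, chloro in place of methyl on an aromatic carbon, para to a large group, gives a 2.2-fold higher number from compound 1 to compound 3 (0.34 log units; beyond the scatter). This position therefore responds to the exchange of one heavy atom for another. Going by these compounds alone, the earlier step concerned a different group and lowered the number, so compound 3 is the first to show a change that raises it. Nothing at hand gives a reason for this rise.

One pair cannot tell how a fluoro, a methoxy or an amine would read at this position. Going by these compounds, whether the same swap would raise the number on the core of compound 2 also stays open.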